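Phenoxy ring substitution in a phosphoserine ester series

A few compounds are considered here, and "the series" means these few. Any claim that something is new, unique, unknown or untested is made for them only; others in the source may bear on it.

Measured compounds:
compound 1, `Cc1ccccc1Oc1cccc(COc2ccccc2CCC(=O)OCCCOP(=O)(O)OC[C@H](N)C(=O)O)c1`, in an assay on cells for activation of probable G-protein coupled receptor 34 (Mus musculus), with a stated time of 1 h (on this read-out lower numbers stand for smaller maximal responses and higher numbers for larger maximal responses), compound 1 gives 0.28
compound 2, `N[C@@H](COP(=O)(O)OCCCOC(=O)CCc1ccccc1OCc1cccc(Oc2ccc(F)cc2)c1)C(=O)O`, in this assay compound 2 gives 0.66

Going by the values given here, compound 2 holds the higher of the two numbers so far. Among the compounds with values here, its nearest neighbour is compound 1, and the single one-place step between them, a number 0.38 higher from compound 1 to compound 2 (beyond the scatter), lies beyond the scatter. That step swaps the whole outer aryl group on the ether oxygen, 4-fluorophenyl in place of 2-methylphenyl.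

Compound 3, `N#Cc1ccc(Oc2cccc(COc3ccccc3CCC(=O)OCCCOP(=O)(O)OC[C@H](N)C(=O)O)c2)cc1`, is not yet measured. Its difference from compound 2 is cyano in place of fluoro on an aromatic carbon. Within the data shown here, no measured step replaces fluoro with cyano anywhere, so the only bearing comes from the large step a number 0.38 higher from compound 1 to compound 2 (beyond the scatter), which shows that the outer aryl group matters to the maximal response. Whether a cyano there moves the number up or down cannot be read from compound 1 and compound 2 alone.

With this in mind, the expected step a number 0.060 lower from compound 2 to compound 3 (within the scatter) is small, with a wide margin. Compound 3 is therefore estimated at 0.6, with a range from 0.3 to 0.9.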

Compound 3, intrinsic activity: the largest response reached, as a fraction of the reference agonist's: 0.041
Estimate against measurement, compound 3: 0.56 above, and the stated range ends above it.
By their numbers in this assay, from the lowest: compound 3; then compound 1; then compound 2.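

In this assay, the group para to a large group on the outer ring strongly shapes the maximal response: cyano in place of fluoro gives a number 0.62 lower from compound 2 to compound 3 (beyond the scatter), although the change only replaces one heavy atom with two. Replacing 2-methylphenyl does not push the response in one fixed direction, since 4-fluorophenyl raises it while 4-cyanophenyl gives a number 0.24 lower from compound 1 to compound 3 (beyond the scatter), so the direction depends on the aryl group that enters. Nothing available on these compounds accounts for the fall in response.

The compounds shown leave open whether the low response belongs to cyano specifically or would also appear with another group at this place, such as an amine, a carboxylic acid or methoxy. The steps from compound 1 change both the substituent and its place on the ring, so 4-methylphenyl or 2-fluorophenyl would be needed to separate those two changes.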